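Swapping the oxime ester tail for an acetyl group

The source may report more compounds than this note shows. Statements on the series, on what has been measured and on what is new or still open speak of the compounds shown alone.

Measured so far:
compound 1, `CCOC(=O)CCO/N=C(/c1ccc(OC)c(OC)c1OC)c1cccc2ccccc12`: 10000 nM
compound 2, `C=CCOC(c1ccc(OC)c(OC)c1OC)c1cccc2ccccc12`: > 20000 nM

In a functional assay on HCT-116 cells (Homo sapiens) for inhibition, read by sulforhodamine B assay, with a stated time of 48 h (on this read-out lower numbers stand for stronger inhibition and higher numbers for weaker inhibition), compound 1 gives 10000 nM, the only plain number among the two results shown, so compound 1 stands alone as the reference point. For compound 2 the result is a limit of the assay rather than a number, > 20000 nM, which is the limit of > 20000 nM in this assay, at which 1 of the 2 values shown sits.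

Compound 3, `COc1ccc(/C(=N/OC(C)=O)c2cccc3ccccc23)c(OC)c1OC`, has not been measured. It differs from compound 1 by acetyl in place of 2-(ethoxycarbonyl)ethyl on an oxygen. Among the measured compounds shown here, no two measured compounds differ in only one place, so no measured step tells how large such a change can be. The expected step from no change at the digits printed from compound 1 to compound 3 (within the scatter) is therefore taken as none beyond the usual scatter, in either direction. Compound 3 is expected to give 10000 nM, with a range from 3000 nM to 30000 nM, and a fair chance that only a limit is reported.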

Compound 3, half-maximal inhibitory concentration: 4980 nM
The estimate for compound 3 lay 2.0-fold (0.30 log units) above the measured number; measured number inside the range.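

Among the compounds shown here, this is the first measured change at a single place. In this assay, acetyl in place of 2-(ethoxycarbonyl)ethyl, on an oxygen whose other neighbour is a double-bonded nitrogen, gives a 2.0-fold lower number from compound 1 to compound 3 (0.30 log units; within the scatter). Compound 1 and compound 3 therefore cannot be told apart on this read-out, so the full ester chain of compound 1 is not needed to keep the number in this range, and nothing shown gives a cause for this result.

Going by these compounds, whether a different group on this oxygen, such as an amine-bearing chain, a chain ending in a carboxylic acid or a plain methyl, would move the number beyond the scatter remains open. A single step also cannot show whether the same swap would behave alike on a different core.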